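Swapping Isopropoxy for Trifluoromethyl in Compound 4

The source may report more compounds than this note shows. Statements on the series, on what has been measured and on what is new or still open speak of the compounds shown alone.

Measured compounds:
compound 1 `O=C(CN1CCC(c2cccc[n+]2[O-])CC1)Nc1ccc(F)cc1F`: 103 nM
compound 2 `CC(C)Oc1cccc(NC(=O)CN2CCC(c3cccc[n+]3[O-])CC2)c1`: 555 nM
compound 3 `Cc1cc(Br)ccc1NC(=O)CN1CCC(c2cccc[n+]2[O-])CC1`: 66 nM

These three share one core and differ only in the aromatic ring on the amide nitrogen. In a functional assay on HEK293 cells for agonist activity at D(4) dopamine receptor (Homo sapiens), read by FLIPR (on this read-out higher numbers stand for an effect only at larger amounts of compound and lower numbers for an effect already at smaller amounts), compound 2 gives the highest number of the three, with compound 1 and compound 3 both beyond the scatter below it. Within the data shown here, the only single-change step measured, a 1.6-fold lower number from compound 1 to compound 3 (0.19 log units; within the scatter), concerns a different ring pattern and says little about compound 2. Compound 4 `O=C(CN1CCC(c2cccc[n+]2[O-])CC1)Nc1cccc(C(F)(F)F)c1` arises from compound 2 by trifluoromethyl in place of isopropoxy on an aromatic carbon. Among the measured compounds shown here, no measured step tests exactly this swap. Compound 1 gives 103 nM and compound 3 gives 66 nM, both lower than compound 2. Compound 4 is therefore expected to move the same way, by about a 2.5-fold lower number from compound 2 to compound 4 (0.40 log units; beyond the scatter). The estimate for compound 4 is 220 nM, within a range from 70 nM to 700 nM.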

Compound 4, half-maximal effective concentration: 76 nM
Beside the measured number, compound 4's estimate is 2.9-fold (0.46 log units) above it; the range from low to high includes it.
By their numbers in this assay, from the lowest: compounds 3, 4 and 1 (each within the scatter of the next); then compound 2.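

Trifluoromethyl in place of isopropoxy on this aromatic carbon gives a 7.3-fold lower number from compound 2 to compound 4 (0.86 log units; beyond the scatter) in this assay, so the group at this place clearly matters. The swap leaves the heavy-atom count unchanged, while isopropoxy has a hydrogen-bond acceptor and trifluoromethyl has none, so size by atom count does not decide the outcome here. Nothing available explains the step.

Going by these compounds, whether a nitrile, an amine or a carboxylic acid at this place would match trifluoromethyl or isopropoxy stays open. So does the effect of the same swap on the other ring patterns.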